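A few compounds are considered here, and "the series" means these few. Any claim that something is new, unique, unknown or untested is made for them only; others in the source may bear on it.

Compound 1, `Cc1ccc(-c2nnc(SCCCN3CCN(c4nc5ccccc5o4)CC3)o2)cc1`, carries a methyl group on an aromatic carbon of a shared core. In a functional assay on MCF7 cells (Homo sapiens) for inhibition, read by MTT assay, with a stated time of 72 h (on this read-out higher numbers stand for weaker inhibition and lower numbers for stronger inhibition), compound 1 gives 60400 nM, the second highest of the three numbers measured. Compound 2, `Fc1ccc(-c2nnc(SCCCN3CCN(c4nc5ccccc5o4)CC3)o2)cc1`, gives 52300 nM in this assay, and compound 3, `Brc1ccc(-c2nnc(SCCCN3CCN(c4nc5ccccc5o4)CC3)o2)cc1`, gives 115000 nM. Compound 4, `c1ccc(-c2nnc(SCCCN3CCN(c4nc5ccccc5o4)CC3)o2)cc1`, differs from compound 1 in one place: hydrogen in place of methyl on an aromatic carbon. For the measured compounds named here, no measured step replaces methyl with hydrogen, but the swaps already made at that aromatic carbon were small: a 1.2-fold lower number from compound 1 to compound 2 (0.06 log units; within the scatter), a 1.9-fold higher number from compound 1 to compound 3 (0.28 log units; within the scatter) and a 2.2-fold higher number from compound 2 to compound 3 (0.34 log units; beyond the scatter). Removing the methyl is therefore expected to leave the number roughly where it is, with a 1.0-fold lower number from compound 1 to compound 4 (0.00 log units; within the scatter) expected to stay within the scatter. Compound 4 is estimated at 60000 nM, with a range from 30000 nM to 120000 nM.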

Compound 4, half-maximal inhibitory concentration: 117000 nM
Compound 4: middle estimate off by 2.0-fold (0.29 log units), on the low side; the measured number falls inside the stated range.
By their numbers in this assay, from the lowest: compounds 2, 1, 3 and 4 (each within the scatter of the next, the first and the last beyond it).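

Removing the substituent altogether gives no new level in this assay: hydrogen in place of methyl gives a 1.9-fold higher number from compound 1 to compound 4 (0.29 log units; within the scatter) and hydrogen in place of bromo gives a 1.0-fold higher number from compound 3 to compound 4 (0.01 log units; within the scatter). Only hydrogen in place of fluoro gives a step beyond the scatter, a modest one, with a 2.2-fold higher number from compound 2 to compound 4 (0.35 log units; beyond the scatter). Nothing measured here bears on the cause of these steps. Open, from the compounds shown here alone, is whether an amine or a carboxylic acid on this aromatic carbon would shift the number further than these four groups do.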